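The source may report more compounds than this note shows. Statements on the series, on what has been measured and on what is new or still open speak of the compounds shown alone.

Compound 1 `Cn1cccc1-c1cc(-c2cccs2)nc(N)c1C#N` was tested in a functional assay on HOP-62 cells (Homo sapiens) for inhibition, read by sulforhodamine B assay, with a stated time of 48 h; a lower number here means a stronger inhibitor of growth, a higher number a weaker inhibitor of growth. In this assay compound 1 reaches only the limit of the assay, > 100000 nM, so no number was obtained for it. A second compound, compound 2 `CC1CCCc2c1[nH]c(=O)c(C#N)c2-c1cccn1C`, was tested in the same way. In this assay compound 2 likewise gives only the limit, > 100000 nM. Compound 1 thus stands at the limit of > 100000 nM in this assay, at which 2 of the 2 values shown sit, with nothing to set it apart from compound 2, since neither gave a measurable number. Within the data shown here, no step between two measured compounds is on record. Compound 3 `Cn1cccc1-c1cc(-c2ccccc2)nc(N)c1C#N` has not yet been tested. It differs from compound 1 in one place: phenyl in place of thiophen-2-yl on an aromatic carbon. Among the measured compounds shown here, with both measured compounds sitting at the limit, there is no measured step to lean on, and nothing in these data suggests that phenyl in place of thiophen-2-yl would bring compound 3 into the measurable range. The step from compound 1 to compound 3 is expected to be none beyond the scatter, a number no higher from compound 1 to compound 3 (the limit leaves the size open). Compound 3 is therefore expected to give roughly 100000 nM, within 40000 nM to 300000 nM, most likely reported again as a limit.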

Compound 3, concentration for 50% growth inhibition: 81300 nM
Compound 3: the middle estimate sits 1.2-fold (0.09 log units) above what was measured; low and high end bracket the measured number.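

In this assay, among these compounds, compound 3, with phenyl on the aromatic carbon next to the ring nitrogen, is the only compound here that gives a true number rather than a limit, so growth inhibition can be read with this group in this position, while the other two results stay at the end of the range: the limit of > 100000 nM in this assay, at which 2 of the 3 values shown sit. Putting phenyl in place of thiophen-2-yl gives an at least 1.2-fold lower number from compound 1 to compound 3 (0.08 log units; that floor lies within the scatter). That figure is only a floor, as compound 1 has a limit and not a number, so the real size of the change could be negligible or much larger, and these data do not establish that phenyl is better than thiophen-2-yl here.

The compounds shown leave open how this position responds to groups of a different kind, such as a dimethylamino group, a carboxylic acid or a simple methyl, any of which would show whether the read-out moves further from the limit. They also leave open whether replacing the 1-methyl-1H-pyrrol-2-yl group or the amino group on the core of compound 3 would change growth inhibition at all.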